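Removing the methyl group: expected effect on cell toxicity

The source may report more compounds than this note shows. Statements on the series, on what has been measured and on what is new or still open speak of the compounds shown alone.

Two mirror-image compounds share one core: compound 1, `Cc1cn([C@@H]2SC[C@@](C)(O)[C@H]2O)c(=O)[nH]c1=O`, and compound 2, `Cc1cn([C@H]2SC[C@](C)(O)[C@@H]2O)c(=O)[nH]c1=O`. In an ADME assay on MRC5 cells (Homo sapiens) for cytotoxicity, read by MTT assay, with a stated time of 48 h (a higher number here means a weaker inhibitor, a lower number a stronger inhibitor), compound 1 gives 269000 nM, and compound 2 gives 290000 nM. The step of a 1.1-fold higher number from compound 1 to compound 2 (0.03 log units; within the scatter) is small, and the pair differs only in the way the three stereocentres are drawn (the fact that compounds 1 and 2 differ only in the configuration as drawn). Compound 2 has the highest of the two numbers, but its neighbour compound 1 sits within the scatter.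

Compound 3, `C[C@]1(O)CS[C@H](n2ccc(=O)[nH]c2=O)[C@H]1O`, is made from compound 2 by the change hydrogen in place of methyl on an aromatic carbon. Going by the values given here, the one measured step, the mirror-image swap, left the methyl untouched, so it gives no direct guide to this change. Both measured compounds are weak in this assay, and nothing in the data points to a shift either way. Compound 3 is therefore expected to stay close to compound 2, with the step of a 1.0-fold higher number from compound 2 to compound 3 (0.01 log units; within the scatter) expected to fall within the scatter. The estimate for compound 3 in this assay is 300000 nM, with a range from 150000 nM to 600000 nM.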

Compound 3, half-maximal inhibitory concentration: 1010000 nM
The estimate for compound 3 lay 3.4-fold (0.53 log units) below the measured number; measured number above the stated range.
By their numbers in this assay, from the lowest: compounds 1 and 2 (each within the scatter of the next); then compound 3.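

In this assay, replacing the methyl with hydrogen on this aromatic carbon gives a 3.5-fold higher number from compound 2 to compound 3 (0.54 log units; beyond the scatter), so the position matters to the read-out even though the change removes only a single carbon atom. Inverting all three stereocentres, by contrast, gives a 1.1-fold higher number from compound 1 to compound 2 (0.03 log units; within the scatter), which means that in this small set the methyl position has a measurable effect on the number, while the mirror-image swap does not. Since a higher number here means a weaker inhibitor, the methyl group of compound 2 goes with stronger activity against these cells than the hydrogen of compound 3, although nothing given here explains why the number moves.

With only methyl and hydrogen shown at this carbon, it remains open how an ethyl group, a longer chain, a chlorine atom or an amine would behave there, and whether any of them would bring the number down or push it up. From the compounds shown here alone, it also remains open whether the same swap of methyl for hydrogen would produce a step of similar size on the mirror-image core of compound 1.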